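The source may hold more compounds than are shown below. What is called first, only, known or untested is meant among the compounds shown, and "the series" means these compounds.

Measured so far, in a functional assay on CHO cells for agonist activity at Alpha-1D adrenergic receptor (Homo sapiens), read by FLIPR and calcium flux; a lower number here means that less compound is needed, a higher number that more compound is needed for the effect:

Compound 1 `CCCS(=O)(=O)Nc1cccc2c1CCC2c1ncc[nH]1` gives only a limit of the assay, > 10000 nM.
Compound 2 `CS(=O)(=O)Nc1cccc2c1CCC2c1ncc[nH]1` gives only a limit of the assay, > 10000 nM.
Compound 3 `COc1c(Cl)ccc2c1CCC2c1ncc[nH]1` gives only a limit of the assay, > 10000 nM.

Compound 2 therefore stands at the limit, not at a number, and the same holds for the other two values shown: all three sit at the limit of > 10000 nM in this assay, at which 3 of the 3 values shown sit. Going by the values given here, the single one-place step among the measured compounds, a step that the two limits leave unreadable from compound 1 to compound 2, with hydrogen in place of ethyl on a saturated chain carbon bound to a sulfonyl sulfur, is left unreadable by the two limits, so no size of step is known in this assay for any change.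

Compound 4 `c1cc(-c2nccs2)c2c(c1)C(c1ncc[nH]1)CC2` differs from compound 2 by 1,3-thiazol-2-yl in place of methanesulfonamido on an aromatic carbon. Among the compounds with values here, no measured step bears on this change; the only step recorded is unreadable, and nothing in the data indicates either direction. The expected step from compound 2 to compound 4 is therefore a number no higher from compound 2 to compound 4 (the limit leaves the size open), set wide. Compound 4 is estimated to give 10000 nM in this assay, within 1500 nM to 60000 nM, with a substantial chance that only a limit is again reported.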

Compound 4, half-maximal effective concentration: 3190 nM
Compound 4: middle estimate off by 3.1-fold (0.50 log units), on the high side; the measured number falls inside the stated range.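

In this assay, the aromatic carbon ortho to a fused ring is now shown to be a place where a change can produce a readable effect: 1,3-thiazol-2-yl in place of methanesulfonamido gives an at least 3.1-fold lower number from compound 2 to compound 4 (0.49 log units; beyond the scatter). The same exchange against the longer sulfonyl chain gives an at least 3.1-fold lower number from compound 1 to compound 4 (0.49 log units; beyond the scatter), so the gain does not depend on which of the two sulfonamides serves as the reference. Compound 4 therefore gives the first actual number in the series, while the other compounds remain at a limit: the limit of > 10000 nM in this assay, at which 3 of the 4 values shown sit.

As far as these compounds go, both steps are open-ended, so their true size remains unknown. From the compounds shown here alone, it also remains open whether the gain is specific to 1,3-thiazol-2-yl or would also appear with an oxazol-2-yl, a phenyl or a simple amine on this carbon.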